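Fluorine on the Pendant Phenyl: Two Matched Pairs

The source may report more compounds than this note shows. Statements on the series, on what has been measured and on what is new or still open speak of the compounds shown alone.

Three compounds of the series carry a measurement in a functional assay on A549 cells (Homo sapiens) for antiproliferative activity, read by MTT assay, with a stated time of 72 h; on this read-out higher numbers stand for weaker inhibition and lower numbers for stronger inhibition. Compound 1 `CNC(=O)c1cc(Oc2ccc(NC(=O)c3cc4cccnc4n(-c4ccc(Br)cc4)c3=O)cc2)ccn1` gives 1050 nM in this assay. Compound 2 `CNC(=O)c1cc(Oc2ccc(NC(=O)c3cc4cccnc4n(-c4ccc(Br)cc4F)c3=O)cc2)ccn1` gives 1420 nM in this assay. Compound 3 `CCNC(=O)c1cc(Oc2ccc(NC(=O)c3cc4cccnc4n(-c4ccccc4)c3=O)cc2)ccn1` gives 160 nM in this assay; it stands lowest of the three, with compound 1 nearest and compound 2 furthest, both beyond the scatter. The difference between the core of compound 3 and the core of compound 1 is not broken down here.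

Compound 4 `CCNC(=O)c1cc(Oc2ccc(NC(=O)c3cc4cccnc4n(-c4ccccc4F)c3=O)cc2)ccn1` is not yet measured. It differs from compound 3 by fluoro in place of hydrogen on an aromatic carbon. The same kind of change is already seen once, from compound 1 to compound 2, where it reads (fluoro in place of hydrogen on an aromatic carbon). Around the place the two differ: in the measured pair the site is also meta to a bromo group, while in compound 4 the ring carries no bromo group. The measured step, a 1.4-fold higher number from compound 1 to compound 2 (0.13 log units; within the scatter), is within the scatter.

For compound 4 a step of about the same size is expected, a 1.3-fold higher number from compound 3 to compound 4 (0.12 log units; within the scatter), because the measured pair shows a 1.4-fold higher number from compound 1 to compound 2 (0.13 log units; within the scatter) and nothing in the series points another way. Compound 4 is therefore estimated at 210 nM in this assay, expected to fall between 100 nM and 450 nM.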

Compound 4, half-maximal inhibitory concentration: 490 nM
The estimate for compound 4 lay 2.3-fold (0.37 log units) below the measured number; the measured number lies above the stated range.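

On the core of compound 3, fluoro in place of hydrogen on the pendant phenyl gives a 3.1-fold higher number from compound 3 to compound 4 (0.49 log units; beyond the scatter) in this assay, so here the step lies beyond the scatter, whereas the earlier step on the core of compound 1 lies within it. Set side by side, the two steps both run towards a higher number, and the gap between them does not exceed what two such steps can differ by through scatter alone: the same change on two cores in this assay, a 1.4-fold higher number (0.13 log units; within the scatter) from compound 1 to compound 2 and a 3.1-fold higher number (0.49 log units; beyond the scatter) from compound 3 to compound 4, 2.3-fold (0.35 log units) apart, within the scatter of two such steps. This shows that, on these two cores, the change can be carried across without any measurable difference in its size, but two matched pairs do not establish a rule for the series, and they do not show that the change is inert on one core and harmful on the other.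

As far as these compounds go, how the same site responds to a chloro, methyl or methoxy group in place of the fluoro stays open, and so does the effect of the same change on a core that differs from compound 3 only by the bromo group or only by the amide chain. Those compounds would show which of the two differences, if either, alters the size of the step.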